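Trading the trifluoromethylphenylamino group for a plain phenyl

A few compounds are considered here, and "the series" means these few. Any claim that something is new, unique, unknown or untested is made for them only; others in the source may bear on it.

Compound 3 `COc1cc(-c2nn(-c3cccc(NC(=O)Nc4cccc(C(F)(F)F)c4)c3)cc2-c2ccncc2)ccc1Cl` carries a (3-(trifluoromethyl)phenyl)amino group on a carbonyl carbon whose other neighbour is an amide-type nitrogen. In a functional assay on NCI-H322M cells (Homo sapiens) for inhibition, read by sulforhodamine B assay, with a stated time of 48 h (a lower number here means that less compound is tolerated, a higher number that more compound is tolerated), compound 3 reaches only the limit > 50000 nM, so its place among the three measured values is known only as a range at the weak end. Compound 1 `COc1cc(-c2nn(-c3cccc(NC(=O)c4ccc(Cl)c(C(F)(F)F)c4)c3)cc2-c2ccncc2)ccc1Cl` likewise gives only the limit > 32500 nM in this assay. Compound 2 `O=C(Nc1cccc(-n2cc(-c3ccncc3)c(-c3ccc(Cl)c(O)c3)n2)c1)Nc1cc(C(F)(F)F)cc(C(F)(F)F)c1`, with a hydroxy in place of the methoxy and a bis(trifluoromethyl)phenyl group, gives 23600 nM in this assay. For the measured compounds named here, the one step that leads into compound 3, a step that the two limits leave unreadable from compound 1 to compound 3, is left unreadable by the two limits the limit of > 32500 nM in this assay, at which 1 of the 3 values shown sits, and (the limit of > 50000 nM in this assay, at which 1 of the 3 values shown sits).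

Compound 4 `COc1cc(-c2nn(-c3cccc(NC(=O)c4ccccc4)c3)cc2-c2ccncc2)ccc1Cl` differs from compound 3 by phenyl in place of (3-(trifluoromethyl)phenyl)amino on a carbonyl carbon. Going by the values given here, no measured step describes this change, and the closest relative, compound 1, also sits at a limit. Compound 4 is therefore expected to remain weak, with an estimated step of an at least 1.1-fold lower number from compound 3 to compound 4 (0.04 log units; that floor lies within the scatter) that stays within the scatter. The value of compound 4 in this assay is estimated at 45000 nM, within 15000 nM to 100000 nM.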

Compound 4, concentration lethal to 50% of the cells: > 100000 nM
Compound 4 ended at the assay's limit; the forecaster's own chance of this, stated with the estimate: 65%; middle value at least 2.2-fold (0.34 log units) from the limit.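

In this assay compound 4 gives > 100000 nM which is a limit of the assay. For the compounds shown here, compound 1, compound 3 and compound 4 all stand at limits, and no step among them can be read. The compounds shown leave open whether phenyl in place of (3-(trifluoromethyl)phenyl)amino on a carbonyl carbon changes the tolerated concentration at all.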